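This account rests on a few compounds, and the source may have more. Where it says the series, first, only, none or still open, it means among the compounds named here.

In a functional assay on HCT-116 cells (Homo sapiens) for cytotoxicity, read by MTT assay, with a stated time of 72 h (on this read-out higher numbers stand for weaker inhibition and lower numbers for stronger inhibition), compound 1, `C[C@H](Nc1c(C(=O)NCc2ccc(F)cc2)nc(Br)c2cccnc12)c1ccccc1`, gives > 20000 nM, which is a limit of the assay and not a number. Compound 2, `O=C(NCc1ccc(F)cc1)c1nc(Br)c2cccnc2c1N1CCNCC1`, gives > 10000 nM, which is likewise only a limit. For the measured compounds named here, compound 2 therefore has no exact standing, and the one other value beside it offers no number for comparison. Going by the values given here, the only measured step is a step that the two limits leave unreadable from compound 1 to compound 2, and with limits at both ends it has no readable size.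

Compound 3, `NCCCCCCNc1c(C(=O)NCc2ccc(F)cc2)nc(Br)c2cccnc12`, carries (6-aminohexyl)amino in place of piperazin-1-yl on an aromatic carbon, para to a bromo group: (6-aminohexyl)amino in place of piperazin-1-yl on an aromatic carbon. The ring of piperazin-1-yl is gone, and an open chain takes its place. The measured step gives no size to carry over, so any expectation in this assay is loose and rests on this structural change alone. A modest move towards stronger inhibition is expected, though another limit would be no surprise. The estimated step is an at least 1.6-fold lower number from compound 2 to compound 3 (0.22 log units; that floor lies within the scatter). For compound 3, the expected value is 6000 nM, with an estimated range from 1500 nM to 20000 nM.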

Compound 3, half-maximal inhibitory concentration: > 10000 nM
Compound 3 was reported as a limit; the forecaster's own chance of this, stated with the estimate: 40%; middle value at least 1.6-fold (0.22 log units) away from the limit.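

In this assay compound 3 gives > 10000 nM, which is a limit of the assay and not a number. With only limits for compound 1, compound 2 and compound 3, none of the steps among them can be read. The compounds shown leave open how (1-phenylethyl)amino, piperazin-1-yl and (6-aminohexyl)amino on the shared core rank against one another.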